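The source may hold more compounds than are shown below. What is called first, only, known or untested is meant among the compounds shown, and "the series" means these compounds.

Of the compounds shown here, three have been measured in a functional assay on FM3A cells (Mus musculus) for cytotoxicity, read by cell counting, with a stated time of 2 days; on this read-out lower numbers stand for stronger inhibition and higher numbers for weaker inhibition. Compound 1 `CC(C)(C)c1ccc(CN2C(=O)S/C(=C\c3ccc(N)cc3)C2=O)cc1` gives 80000 nM in this assay, and compound 2 `Nc1ccc(/C=C2\SC(=O)N(Cc3ccc(Cl)cc3)C2=O)cc1` gives 60000 nM. These two share a core and differ only at one aromatic carbon, and the step of a 1.3-fold lower number from compound 1 to compound 2 (0.12 log units; within the scatter) shows that this change made no difference that can be trusted. Compound 3 `C=C(Br)C(=O)Nc1ccc(/C=C2\SC(=O)N(Cc3cccc(Cl)c3)C2=O)cc1` gives 6100 nM, the lowest number of the three and clearly set apart from both compound 1 and compound 2, with the nearer of them, compound 2, a good deal higher.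

Compound 4 `C=C(Br)C(=O)Nc1ccc(/C=C2\SC(=O)N(Cc3ccccc3)C2=O)cc1` is not yet measured. It differs from compound 3 only by hydrogen in place of chloro on an aromatic carbon. Going by the values given here, the single measured step, the one from compound 1 to compound 2, also concerns a substituent on that same ring and stayed within the scatter, but it swaps one group for another rather than removing chloro altogether, so it bears on the present change only loosely. Among the compounds with values here, no measured pair shows what taking chloro off this ring does. On this basis the expected step of a 1.3-fold higher number from compound 3 to compound 4 (0.12 log units; within the scatter) is small, with no clear direction. Compound 4 is therefore estimated at 8000 nM, within a range from 2500 nM to 25000 nM.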

Compound 4, half-maximal inhibitory concentration: 3000 nM
Compound 4: the middle estimate sits 2.7-fold (0.43 log units) above what was measured; measured number inside the range.
By their numbers in this assay, from the lowest: compound 4; then compound 3; then compounds 2 and 1 (each within the scatter of the next).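

Taking the chloro group off the ring in the 3-chlorobenzyl to benzyl change gives, in this assay, a 2.0-fold lower number from compound 3 to compound 4 (0.31 log units; beyond the scatter). Going by these compounds alone, this is the first measured case in which a substituent on this ring is removed rather than swapped for another, and it shows that chloro at this place is not needed to reach the low numbers seen for compound 3 and compound 4; the bare phenyl ring does better, though only by a modest step. No measurement available here explains this step.

The finding rests on a single pair of compounds, so it cannot say whether hydrogen in place of chloro would give a similar step on a different core, such as the one with the plain amine in compound 2. It also leaves open how other groups at this same ring carbon, such as fluoro, methoxy, an amine or a carboxylic acid, would compare with hydrogen and chloro in this assay, and whether any of them would bring the number lower still.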